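A few compounds are considered here, and "the series" means these few. Any claim that something is new, unique, unknown or untested is made for them only; others in the source may bear on it.

Measured compounds:
Compound 1, `CC(C)c1c(C(=O)NCc2ccccc2)nn(-c2ccc(F)cc2)c1OC[C@@H](O)C[C@@H](O)CC(=O)O` — 3.8 nM
Compound 2, `CC(C)c1c(C(=O)NCc2ccccc2Cl)nn(-c2ccc(F)cc2)c1OC[C@@H](O)C[C@@H](O)CC(=O)O` — 9.5 nM

Both compounds share one core and differ only in the benzyl ring of the amide. In an assay on microsomes from liver for inhibition of 3-hydroxy-3-methylglutaryl-coenzyme A reductase (Rattus norvegicus) (a higher number here means a weaker inhibitor, a lower number a stronger inhibitor), compound 1 gives 3.8 nM, while compound 2 gives 9.5 nM. The step of a 2.5-fold higher number from compound 1 to compound 2 (0.40 log units; beyond the scatter) is the only one available, and it places compound 2 as the weaker of the two inhibitors.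

Compound 3, `Cc1cccc(CN(C)C(=O)c2nn(-c3ccc(F)cc3)c(OC[C@@H](O)C[C@@H](O)CC(=O)O)c2C(C)C)c1`, is not yet measured. It arises from compound 2 by the change (methyl(3-methylbenzyl)amino in place of (2-chlorobenzyl)amino on a carbonyl carbon). Going by the values given here, this change is larger than the one between compound 1 and compound 2: it moves a methyl onto the ring in place of the chloro, and it also replaces the amide hydrogen with a methyl, so that the one hydrogen-bond donor is lost. Among the compounds with values here, only the step of a 2.5-fold higher number from compound 1 to compound 2 (0.40 log units; beyond the scatter) bears on it, and it concerns the ring substituent alone; nothing measured here speaks to the loss of the amide hydrogen. A modest weakening is therefore expected in this assay, with wide uncertainty, the step of a 2.6-fold higher number from compound 2 to compound 3 (0.42 log units; beyond the scatter) being the estimated size. Compound 3 is expected at 25 nM, within the range 7 nM to 90 nM.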

Compound 3, half-maximal inhibitory concentration: 37 nM
Beside the measured number, compound 3's estimate is 1.5-fold (0.17 log units) below it, and the stated range covers the measured number.
By their numbers in this assay, from the lowest: compound 1; then compound 2; then compound 3.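

Compound 3 shows that this position, the group on a carbonyl carbon, can lose more in this assay than the chloro step alone suggested: a 3.9-fold higher number from compound 2 to compound 3 (0.59 log units; beyond the scatter) and, measured against the unsubstituted benzylamino group, a 9.7-fold higher number from compound 1 to compound 3 (0.99 log units; beyond the scatter). Going by these compounds alone, this is also the first change here that removes the hydrogen-bond donor of the group, as methyl(3-methylbenzyl)amino has none while benzylamino and (2-chlorobenzyl)amino each have one, although the aromatic ring stays in place and compound 3 remains a measurable inhibitor at 37 nM. No measurement at hand explains why the number rises with this change.

The added methyl on the nitrogen and the methyl on the ring arrive together, so these compounds cannot show how much of the rise belongs to each. Compounds carrying (3-methylbenzyl)amino or methyl(benzyl)amino on the same carbonyl carbon would separate the two contributions, while a group such as 2-phenylethylamino, with a longer chain, would test how the distance from the carbonyl carbon to the aromatic ring affects the number.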